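What Loss of the Chloro Group May Do

The source may hold more compounds than are shown below. What is called first, only, known or untested is meant among the compounds shown, and "the series" means these compounds.

In an ADME assay on HeLa cells (Homo sapiens) for cytotoxicity (on this read-out lower numbers stand for higher toxicity in this test and higher numbers for lower toxicity in this test), compound 1 (`CCN(CC)CN1C(=O)/C(=N/NC(N)=S)c2cc(Cl)ccc21`) gives > 100000 nM as its result, which is a limit and not a number.

Compound 2 (`CCN(CC)CN1C(=O)/C(=N/NC(=S)Nc2ccc(OC)cc2)c2cc(Cl)ccc21`) carries 4-methoxyphenyl in place of hydrogen on an amide-type nitrogen and gives 13200 nM in this assay as a measured number. Compound 3 (`CCN(CC)CN1C(=O)/C(=N/NC(N)=S)c2ccccc21`) differs from compound 1 elsewhere on the shared core, with hydrogen in place of chloro on an aromatic carbon as the difference: hydrogen in place of chloro on an aromatic carbon.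

Among the compounds with values here, the only measured step (an at least 7.5-fold lower number from compound 1 to compound 2 (0.87 log units; beyond the scatter)) lies at that nitrogen and gives no size for this change, so no step beyond the scatter is expected in this assay in either direction. The estimated change is a number no higher from compound 1 to compound 3 (the limit leaves the size open) on this reasoning, and the result may again be only a limit. For compound 3 the expected value is 100000 nM within an estimated range of 40000 nM to 250000 nM in the same test.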

Compound 3, half-maximal cytotoxic concentration: > 100000 nM
Compound 3: only a limit was reported; the forecaster's own chance of this, stated with the estimate: 70%; the middle value sits exactly at the limit.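

In this assay compound 3 gives > 100000 nM as a limit and not a number. Compound 1 also stands at a limit, so the step between compound 1 and compound 3 cannot be read. The compounds shown leave open whether hydrogen in place of chloro on an aromatic carbon changes this read-out at all.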